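This account rests on a few compounds, and the source may have more. Where it says the series, first, only, none or still open, it means among the compounds named here.

- compound 1 `COc1ccc(S(=O)(=O)n2cc(/C=C/C(=O)c3ccncc3)c3ccccc32)cc1`: 26000 nM
- compound 2 `CCCS(=O)(=O)n1cc(/C=C/C(=O)c2ccncc2)c2ccccc21`: 46200 nM
- compound 3 `O=C(/C=C/c1cn(S(=O)(=O)c2ccc(Cl)cc2)c2ccccc12)c1ccncc1`: 35100 nM

All three values come from a functional assay on HepG2 cells (Homo sapiens) for antiproliferative activity, read by MTT assay, with a stated time of 48 h; a lower number here means a stronger inhibitor, a higher number a weaker inhibitor. Compound 3 , at 35100 nM, cannot be ranked against the other two: the steps are a 1.4-fold higher number from compound 1 to compound 3 (0.13 log units; within the scatter) and a 1.3-fold lower number from compound 2 to compound 3 (0.12 log units; within the scatter).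

Next in the series is compound 4 `CC(C)(C)c1ccc(S(=O)(=O)n2cc(/C=C/C(=O)c3ccncc3)c3ccccc32)cc1`, with tert-butyl in place of chloro on an aromatic carbon, para to a large group: tert-butyl in place of chloro on an aromatic carbon. The closest measured precedent is the exchange at that same aromatic carbon, a 1.4-fold higher number from compound 1 to compound 3 (0.13 log units; within the scatter). Replacing the whole aryl group with propyl, or the reverse, also left the number within the scatter: a 1.8-fold higher number from compound 1 to compound 2 (0.25 log units; within the scatter) and a 1.3-fold lower number from compound 2 to compound 3 (0.12 log units; within the scatter). For the measured compounds named here, no measured compound carries tert-butyl, so this precedent is indirect. No step beyond the scatter is therefore expected in this assay.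

The expected step is a 1.2-fold lower number from compound 3 to compound 4 (0.07 log units; within the scatter).

For compound 4 the estimated value is 30000 nM, with an expected range from 14000 nM to 62000 nM.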

Compound 4, half-maximal inhibitory concentration: 27000 nM
Compound 4: the middle estimate sits 1.1-fold (0.05 log units) above what was measured; the range from low to high includes it.
By their numbers in this assay, from the lowest: compounds 1, 4, 3 and 2 (each within the scatter of the next).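

In this assay, tert-butyl with 4 heavy atoms, on the aromatic carbon para to a large group, stays within the scatter of chloro with 1 heavy atom (a 1.3-fold lower number from compound 3 to compound 4 (0.11 log units; within the scatter)) and of methoxy (a 1.0-fold higher number from compound 1 to compound 4 (0.02 log units; within the scatter)). Exchanging the whole 4-(tert-butyl)phenyl for propyl on the sulfonyl sulfur also stays within the scatter (a 1.7-fold lower number from compound 2 to compound 4 (0.23 log units; within the scatter)), so none of the four compounds can be separated from the others by its number. Nothing available bears on why these numbers stay together.

As far as these compounds go, whether an amine or a carboxylic acid on that aromatic carbon, or a longer chain on the sulfonyl sulfur, would give a step beyond the scatter stays open. From the compounds shown here alone, the rest of the shared core is constant across all four compounds, so the outcome of replacing its carbonyl with an amide also stays open.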